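Swapping a side group on compound 2

This account rests on a few compounds, and the source may have more. Where it says the series, first, only, none or still open, it means among the compounds named here.

Compound 1 (`C[Se]c1ccc(N(C)c2nc(C3CC3)nc3ccccc23)cc1`): 11 nM 
Compound 2 (`COc1ccc(N(C)c2nc(C)nc3ccccc23)cc1C(=O)OCCC[Se]C#N`): 854 nM 
Compound 3 (`Cc1nc(N(C)c2ccc(OCC[Se]C#N)cc2)c2ccccc2n1`): 547 nM 

These three compounds were tested in a functional assay on LoVo cells (Homo sapiens) for inhibition, read by MTT assay, with a stated time of 48 h (on this read-out lower numbers stand for stronger inhibition and higher numbers for weaker inhibition), and their numbers fall into two groups. Compound 2 (854 nM) sits at the upper end of the numbers, within the usual scatter of compound 3 (547 nM). Compound 1 (11 nM) has a far lower number, well beyond that scatter, so compound 2 is clearly weaker than compound 1.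

The next compound to be measured is compound 4 (`COc1ccc(N(C)c2nc(C)nc3ccccc23)cc1OCCCC[Se]C#N`). Compared with compound 2, one side group changes: a group of 8 heavy atoms (5 carbon, 1 nitrogen, 1 oxygen, 1 selenium; no ring) in place of a group of 9 heavy atoms (5 carbon, 1 nitrogen, 2 oxygen, 1 selenium; no ring), on an aromatic carbon. The change sits on an aromatic carbon, ortho to a methoxy group, and the group that leaves holds a double bond outside aromatic rings, while the group that enters holds none.

For the measured compounds named here, no measured pair shows this exact change, so the evidence is thin. Still, compound 2 (854 nM) and compound 3 (547 nM) carry different side groups, and their values stay within the scatter of each other. A small shift towards a lower number, within the scatter, is therefore expected for a 1.7-fold lower number from compound 2 to compound 4 (0.23 log units; within the scatter) in this assay, though a larger move cannot be ruled out. Compound 4 is estimated at 500 nM (expected range 150 nM to 1500 nM).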

Compound 4, half-maximal inhibitory concentration: 882 nM
The estimate for compound 4 lay 1.8-fold (0.25 log units) below the measured number; the measured number falls inside the stated range.
By their numbers in this assay, from the lowest: compound 1; then compounds 3, 2 and 4 (each within the scatter of the next).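

Putting a group of 8 heavy atoms with no double bond in place of a group of 9 heavy atoms with one double bond gives a 1.0-fold higher number from compound 2 to compound 4 (0.01 log units; within the scatter) in this assay. For the compounds shown here, this is the first pair of compounds that differ only at this place, on an aromatic carbon ortho to a methoxy group, and it shows that, for this pair, the double bond and the second oxygen of the group that leaves are not needed to keep the number where it stands. Nothing available explains why the two groups give such closely matched numbers.

This is still a single pair in a single assay, and both groups keep the selenium and the triple bond, so it says nothing about how much those parts contribute. On these data alone, whether an amine, a carboxylic acid or a longer chain on this aromatic carbon would also leave the number within the scatter remains open.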